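The compounds below may be only part of what the source reports. "The series", "measured", "known", "first", "only" and "open" are said of these compounds alone.

Measured compounds in a functional assay on COLO 205 cells (Homo sapiens) for inhibition, read by sulforhodamine B assay, with a stated time of 48 h; on this read-out lower numbers stand for stronger inhibition and higher numbers for weaker inhibition:
Compound 1, `Cc1ccc2occ(C3N=C(c4ccccc4)SS3)c(=O)c2c1`, gives > 100000 nM, a limit of the assay.
Compound 2, `O=c1c(C2N=C(c3ccccc3)SS2)coc2ccc(Cl)cc12`, gives > 100000 nM, a limit of the assay.
Compound 3, `O=c1c(C2N=C(c3ccccc3)SS2)coc2ccc(F)cc12`, gives > 100000 nM, a limit of the assay.

Compound 3 therefore stands only at a limit, as do the other two; all three values share (the limit of > 100000 nM in this assay, at which 3 of the 3 values shown sit). The steps a step that the two limits leave unreadable from compound 1 to compound 2, a step that the two limits leave unreadable from compound 1 to compound 3 and a step that the two limits leave unreadable from compound 2 to compound 3 cannot be sized from two limits. Compound 4, `O=c1c(C2N=C(c3ccccc3)SS2)coc2ccccc12`, differs from compound 3 by hydrogen in place of fluoro on an aromatic carbon. Among the measured compounds shown here, none of the measured steps bears a readable size on this change, so no direction beyond the scatter is expected in this assay; compound 4 is expected to sit at the limit as well, a step that the limit leaves unreadable from compound 3 to compound 4. The estimate for compound 4 is 150000 nM, with a range from 30000 nM to 1000000 nM.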

Compound 4, half-maximal inhibitory concentration: > 100000 nM
Compound 4: a limit, no number (the forecaster's own chance of this, stated with the estimate: 85%); the middle value is on the limit's open side.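

No step can be read among compound 1, compound 2, compound 3 and compound 4 in this assay, as all four values are limits: the limit of > 100000 nM in this assay, at which 4 of the 4 values shown sit. The compounds shown leave open what change to the shared core, if any, would give a measurable value.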